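Adding a second chloro to compound 2

A few compounds are considered here, and "the series" means these few. Any claim that something is new, unique, unknown or untested is made for them only; others in the source may bear on it.

Compound 2 `COc1cc(/C=C/C(=O)c2cccc(NC(=O)c3ccc(Cl)cc3)c2)ccc1O` stands lowest of the two numbers in a functional assay on HUVEC cells (Homo sapiens) for inhibition, tested at 5 ug/mL (on this read-out higher numbers stand for a stronger effect at the one concentration tested and lower numbers for a weaker effect), where compound 2 gives 42%. For the measured compounds named here, compound 1 `COc1cc(/C=C/C(=O)c2cccc(NC(=O)c3cccs3)c2)ccc1O` in this assay gives 80%, and the single measured step, a number 38 percentage points lower from compound 1 to compound 2 (beyond the scatter), concerns a different change, an exchange of the whole aryl on the carbonyl carbon. Compound 3 `COc1cc(/C=C/C(=O)c2cccc(NC(=O)c3ccc(Cl)c(Cl)c3)c2)ccc1O` differs from compound 2 by chloro in place of hydrogen on an aromatic carbon, sitting ortho to a chloro group and meta to a large group. Going by the values given here, no measured step covers a chloro entering in place of hydrogen, so no direction can be read from the series. The step of a number 3 percentage points higher from compound 2 to compound 3 (within the scatter) is therefore expected to stay within the scatter. Compound 3 is estimated at 45%, within 20% to 70%.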

Compound 3, a percentage reported as inhibition, at one concentration (the size of the read-out at that concentration, not a potency): 5%
Compound 3: middle estimate off by 40 percentage points, on the high side; measured number outside the range, below it.
By their numbers in this assay, from the lowest: compound 3; then compound 2; then compound 1.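

In this assay, a chloro in place of hydrogen on this aromatic carbon, ortho to a chloro group and meta to a large group, is no neutral change (a number 37 percentage points lower from compound 2 to compound 3 (beyond the scatter)). A single added chloro therefore moves the read-out about as far as the whole aryl exchange did, and the 3,4-dichlorophenyl group stands far from thiophen-2-yl (a number 75 percentage points lower from compound 1 to compound 3 (beyond the scatter)). Nothing available explains the drop.

Open, on these data alone, is whether a methoxy or an amine at this position would give the same loss. Also open, as far as these compounds go, is whether a chloro here needs the existing 4-chloro to have this effect.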